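Compound 2 and the acetamido change

The source may report more compounds than this note shows. Statements on the series, on what has been measured and on what is new or still open speak of the compounds shown alone.

Measured in a functional assay on HCT-15 cells (Homo sapiens); a lower number here means that less compound is needed, a higher number that more compound is needed for the effect:
- Compound 1 `COc1cc(C2OC(c3ccc(N(C)C)cc3)=NN2C=O)cc(OC)c1OC`: 0.096 uM
- Compound 2 `COc1cc(C2OC(c3ccc(N(C)C)cc3)=NN2C(=O)CN(C)C)cc(OC)c1OC`: 80 uM

Compound 2 holds the higher of the two numbers, at 80 uM. Compound 3 `COc1cc(C2OC(c3ccc(N(C)C)cc3)=NN2C(=O)CNC(C)=O)cc(OC)c1OC`, not yet measured, has acetamido in place of dimethylamino on a saturated chain carbon bound to a carbonyl carbon. Among the measured compounds shown here, only one measured step bears on this change: an 830-fold higher number from compound 1 to compound 2 (2.92 log units; beyond the scatter). That step brought in the (dimethylamino)methyl group, and compound 3 keeps the methyl carbon of that group but not its dimethylamino. For the measured compounds named here, no measured pair shows the effect of acetamido, so the reading is uncertain. Compound 2 stands so high that a fall is more likely than a further rise. The expected change is a 10-fold lower number from compound 2 to compound 3 (1.00 log units; beyond the scatter), which would leave most of the gap in place. For compound 3 the estimated value in this assay is 8 uM, with an expected range from 0.8 uM to 80 uM.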

Compound 3, concentration for half-maximal effect: 0.18 uM
Estimate against measurement, compound 3: 44-fold (1.65 log units) above; measured number below the stated range.
By their numbers in this assay, from the lowest: compounds 1 and 3 (each within the scatter of the next); then compound 2.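

In this assay the acetamido group on a saturated chain carbon bound to a carbonyl carbon gives a 440-fold lower number from compound 2 to compound 3 (2.65 log units; beyond the scatter) and so shows that this position is not closed to substitution: among these compounds, the high number goes with the dimethylamino group and not with the added chain as such. The acetamidomethyl group in place of hydrogen on a carbonyl carbon gives a 1.9-fold higher number from compound 1 to compound 3 (0.27 log units; within the scatter) and thus shows that this chain can stand here with no change beyond the scatter. Nothing measured here explains the difference between dimethylamino and acetamido.

The compounds shown leave open how a primary amine, a carboxylic acid or a longer chain at this place would read in this assay and whether the large step is specific to dimethylamino. They also leave open whether the acetamido result would hold on any other core.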